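Fluorine relocation on the aryl group of compound 3

The source may report more compounds than this note shows. Statements on the series, on what has been measured and on what is new or still open speak of the compounds shown alone.

Compound 3 `Brc1ccc(-c2cn3ccnc3c(-c3ccc4ncn(C5CCCCC5)c4c3)n2)cc1` stands highest of the three numbers in a functional assay on 786-0 cells (Homo sapiens) for inhibition, read by sulforhodamine B assay, with a stated time of 48 h, tested at 10 uM (on this read-out lower numbers stand for less inhibition and higher numbers for more inhibition at the one concentration tested (going by the name of the read-out)), where compound 3 gives 18%. Its nearest neighbour is compound 1 `Fc1ccc(-c2cn3ccnc3c(-c3ccc4ncn(C5CCCCC5)c4c3)n2)cc1`, which in this assay gives 11.2%, the gap being a number 6.8 percentage points higher from compound 1 to compound 3 (within the scatter). The furthest is compound 2 `c1cn2cc(-c3ccsc3)nc(-c3ccc4ncn(C5CCCCC5)c4c3)c2n1`, which gives 6.35%; the difference a number 11.7 percentage points higher from compound 2 to compound 3 (beyond the scatter) is the only one in the set beyond the scatter, while a number 4.9 percentage points lower from compound 1 to compound 2 (within the scatter) is not.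

Compound 4 `Fc1ccccc1-c1cn2ccnc2c(-c2ccc3ncn(C4CCCCC4)c3c2)n1` carries the change (2-fluorophenyl in place of 4-bromophenyl on an aromatic carbon). Going by the values given here, the one measured step that bears on it is the halogen exchange, fluoro for bromo, which gave a number 6.8 percentage points higher from compound 1 to compound 3 (within the scatter), within the scatter. Among the compounds with values here, no measured pair shows what moving the fluorine to the 2-position of the phenyl does, so that part of the change is uncovered. The expectation for compound 4 is therefore a number close to that of compound 1, with a step from compound 3 of a number 7 percentage points lower from compound 3 to compound 4 (within the scatter), not beyond the scatter. Compound 4 is estimated in this assay at 11%, in the range 2% to 22%.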

Compound 4, a percentage reported as inhibition, at one concentration (the size of the read-out at that concentration, not a potency): 2.94%
Compound 4: middle estimate off by 8.1 percentage points, on the high side; measured number inside the range.
By their numbers in this assay, from the lowest: compounds 4, 2, 1 and 3 (each within the scatter of the next, the first and the last beyond it).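

In this assay, the change from the 4-bromophenyl group to the 2-fluorophenyl group gives a step beyond the scatter (a number 15.1 percentage points lower from compound 3 to compound 4 (beyond the scatter)), so this position can register a replacement of the aryl group even though the number stays low. Neither of the other steps to compound 4 can be separated from the scatter (a number 8.3 percentage points lower from compound 1 to compound 4 (within the scatter); a number 3.4 percentage points lower from compound 2 to compound 4 (within the scatter)), so the 2-fluorophenyl group is not distinguished here from either the 4-fluorophenyl or the thiophen-3-yl group. Nothing available explains the step from the 4-bromophenyl group.

Going by these compounds, whether the halogen or its place on the phenyl ring carries the step stays open, and a 2-bromophenyl group would bear on that. Also open, on these data alone, is how a phenyl group carrying an amine or a carboxylic acid would read at this position.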